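Swapping a tetrazole for a pyridinyl-pyrazole on the piperidine

The compounds below may be only part of what the source reports. "The series", "measured", "known", "first", "only" and "open" are said of these compounds alone.

Measured so far:
compound 1 `O=C(CCN1CCC(n2ncnn2)CC1)N1CCC[C@H]1c1nc2cc(Cl)c(Cl)cc2[nH]1` gives 2900 nM in an assay on a cell-free system (plasma) for inhibition of lysosomal Pro-X carboxypeptidase (Mus musculus); a lower number here means a stronger inhibitor, a higher number a weaker inhibitor;
compound 2 `O=C(CCN1CCC(c2nc(-c3ncccn3)no2)CC1)N1CCC[C@H]1c1nc2cc(Cl)c(Cl)cc2[nH]1` gives 745 nM in this assay;
compound 3 `CC(C)(CCCC(=O)N1CCC[C@H]1c1nc2cc(Cl)c(Cl)cc2[nH]1)N1CCC(c2nc(-c3ccccn3)no2)CC1` gives 113 nM in this assay.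

Compound 1 has the highest number of the three, so it is the weakest inhibitor in this set; compound 2 sits nearest to it and compound 3 furthest, with a much lower number.

The new compound 4 `O=C(CCN1CCC(c2cc(-c3ccncc3)[nH]n2)CC1)N1CCC[C@H]1c1nc2cc(Cl)c(Cl)cc2[nH]1` differs from compound 1 in a single place: 5-(pyridin-4-yl)-1H-pyrazol-3-yl in place of 2H-tetrazol-2-yl on a saturated ring carbon. Going by the values given here, the only measured step that bears on this change is the one from compound 1 to compound 2, where a small five-membered ring on the same saturated ring carbon was replaced by a larger two-ring group, giving a 3.9-fold lower number from compound 1 to compound 2 (0.59 log units; beyond the scatter). Compound 3 carries a related two-ring group but also a different linker, so it is not a clean comparison; its value only shows that such groups can go together with a much lower number.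

The change to compound 4 again replaces the small ring with a larger two-ring group, so a modest step to a lower number is expected in this assay, of about a 3.2-fold lower number from compound 1 to compound 4 (0.51 log units; beyond the scatter). Compound 4 is therefore estimated at 900 nM, with a likely range from 300 nM to 3000 nM.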

Compound 4, half-maximal inhibitory concentration: 485 nM
Beside the measured number, compound 4's estimate is 1.9-fold (0.27 log units) above it; measured number inside the range.
By their numbers in this assay, from the lowest: compound 3; then compounds 4 and 2 (each within the scatter of the next); then compound 1.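

In this assay the change from 2H-tetrazol-2-yl to 5-(pyridin-4-yl)-1H-pyrazol-3-yl on this saturated ring carbon gives a 6.0-fold lower number from compound 1 to compound 4 (0.78 log units; beyond the scatter) and so shows that compound 2 is not alone: a second two-ring group at this position also goes with a lower number than the tetrazole. The two larger groups differ in both of their rings, yet the step between them is a 1.5-fold lower number from compound 2 to compound 4 (0.19 log units; within the scatter) and so gives no ground for ranking one above the other in this small set. Nothing at hand explains why the larger groups go with lower numbers.

The compounds shown leave open whether the second ring is needed at all, since a simple amine or a lone pyrazole on this ring carbon would test that, and whether a plain phenyl ring would serve as well as the pyridine. They also leave open how much of the low number of compound 3 belongs to its longer chain, which could be read only from a pair that differs in that chain alone.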